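Shifting the Iodine Along the Benzyl Ring

The source may report more compounds than this note shows. Statements on the series, on what has been measured and on what is new or still open speak of the compounds shown alone.

Compound 1 `OC[C@H]1O[C@@H](n2cnc3c(SCc4ccccc4Br)ncnc32)[C@H](O)[C@@H]1O` gives 134 nM in an assay on K562 cells for displacement of a labelled ligand from Equilibrative nucleoside transporter 1 (Homo sapiens); a lower number here means a stronger inhibitor, a higher number a weaker inhibitor.
Compound 2 `OC[C@H]1O[C@@H](n2cnc3c(SCc4cccc(Cl)c4)ncnc32)[C@H](O)[C@@H]1O` gives 16 nM in this assay.
Compound 3 `OC[C@H]1O[C@@H](n2cnc3c(SCc4ccccc4I)ncnc32)[C@H](O)[C@@H]1O` gives 16.1 nM in this assay.

Compound 3 holds the second highest of the three numbers; its value and that of compound 2 sit within the scatter of each other, while an 8.3-fold lower number from compound 1 to compound 3 (0.92 log units; beyond the scatter) sets it well apart from compound 1. Compound 4 `OC[C@H]1O[C@@H](n2cnc3c(SCc4cccc(I)c4)ncnc32)[C@H](O)[C@@H]1O` carries 3-iodophenyl in place of 2-iodophenyl on a saturated chain carbon bound to a sulfur. For the measured compounds named here, no measured step moves the same halogen alone: an 8.4-fold lower number from compound 1 to compound 2 (0.92 log units; beyond the scatter) and a 1.0-fold higher number from compound 2 to compound 3 (0.00 log units; within the scatter) each mix a change of halogen with a change of position, so they bear only loosely on this step. Compound 2 with its 3-chlorophenyl gives 16 nM, a useful anchor. Compound 4 is therefore expected to land nearby, with a 1.3-fold lower number from compound 3 to compound 4 (0.13 log units; within the scatter). The estimate for compound 4 is 12 nM, within 4 nM to 40 nM.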

Compound 4, inhibition constant: 13.8 nM
For compound 4 the middle estimate is 1.2-fold (0.06 log units) below the measured one; measured number inside the range.
By their numbers in this assay, from the lowest: compounds 4, 2 and 3 (each within the scatter of the next); then compound 1.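

For the compounds shown here, for the first time one halogen moves alone on the ring, and with a 1.2-fold lower number from compound 3 to compound 4 (0.07 log units; within the scatter) in this assay the 2-iodophenyl and 3-iodophenyl groups cannot be told apart. Exchanging the halogen on the same carbon gives a 1.2-fold lower number from compound 2 to compound 4 (0.06 log units; within the scatter) and is equally unresolved. Only compound 1 stands apart, with a 9.7-fold lower number from compound 1 to compound 4 (0.99 log units; beyond the scatter) marking the one clear gap.

Nothing available explains that gap with the 2-bromophenyl group. From the compounds shown here alone, whether a methoxy group or an amine on this ring would match the halogens remains open.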